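The source may report more compounds than this note shows. Statements on the series, on what has been measured and on what is new or still open speak of the compounds shown alone.

Working notes on the step from compound 2 `Cc1ccc(-c2nc(CN3CCC(C(=O)NCCCN4C[C@H](C)C[C@H](C)C4)CC3)c(C)o2)cc1` to compound 3 `COc1cccc(C)c1-c1nc(CN2CCC(C(=O)NCCCN3C[C@H](C)C[C@H](C)C3)CC2)c(C)o1`. In an ADME assay on microsomes from liver (Rattus norvegicus) for metabolic stability, read by LC-MS, using NADPH, at 37 degrees C (a lower number here means that the compound disappears faster, a higher number that the compound lasts longer), compound 2 gives > 0.5 h, which is a limit of the assay and not a number. In this assay compound 1 `Cc1oc(-c2c(Br)cccc2Br)nc1CN1CCC(C(=O)NCCCN2C[C@H](C)C[C@H](C)C2)CC1` gives 0.035 h. The change to compound 3 is 2-methoxy-6-methylphenyl in place of 4-methylphenyl on an aromatic carbon, next to the ring nitrogen and next to the ring oxygen: 2-methoxy-6-methylphenyl in place of 4-methylphenyl on an aromatic carbon. The name of the entering group shares its numbering with the 2,6-dibromophenyl of compound 1, not with the leaving 4-methylphenyl. Among the compounds with values here, only one measured step bears on this change, and it is large: an at least 14-fold higher number from compound 1 to compound 2 (1.15 log units; beyond the scatter), with 4-methylphenyl in place of 2,6-dibromophenyl. On the strength of an at least 14-fold higher number from compound 1 to compound 2 (1.15 log units; beyond the scatter) a move in the reverse direction is expected, though smaller, as this rests on a single pair and the groups differ. The expected change is an at least 5.0-fold lower number from compound 2 to compound 3 (0.69 log units; beyond the scatter). The half-life of compound 3 is estimated at 0.1 h, with an expected range of 0.03 h to 0.4 h.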

Compound 3, half-life: 0.0767 h
Compound 3: the middle estimate sits 1.3-fold (0.12 log units) above what was measured, within the range that was stated.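

In this assay the 2-methoxy-6-methylphenyl group on this aromatic carbon brings an at least 6.5-fold lower number from compound 2 to compound 3 (0.81 log units; beyond the scatter); with it, the 2,6-dibromophenyl group of compound 1 and the 2-methoxy-6-methylphenyl group of compound 3 both give short half-lives, while the 4-methylphenyl group of compound 2 stands apart from them. Compound 2 gives > 0.5 h, which is a limit of the assay and not a number, and the step out of it can be read only as a bound because of where compound 2 stands: the limit of > 0.5 h in this assay, at which 1 of the 3 values shown sits. The identity of these two groups also counts, though modestly, since replacing 2,6-dibromophenyl with 2-methoxy-6-methylphenyl gives a 2.2-fold higher number from compound 1 to compound 3 (0.34 log units; beyond the scatter).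

With three compounds, the short half-lives cannot yet be tied to the numbering these two groups share rather than to the particular groups, since the 4-methylphenyl group differs from both in more than where its substituent sits. Going by these compounds, a plain phenyl, a 2-methylphenyl or a 2,6-dimethylphenyl group on this carbon would separate these readings, and the true half-life of compound 2 remains unknown behind its limit.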